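A few compounds are considered here, and "the series" means these few. Any claim that something is new, unique, unknown or untested is made for them only; others in the source may bear on it.

Compound 1 `COc1cccc(CNC(=O)c2c[nH]c3cc(-c4cn[nH]c4)ccc23)c1` sits at the limit of an assay on isolated protein for inhibition of Rho-associated protein kinase 2 (Homo sapiens) (a lower number here means a stronger inhibitor, a higher number a weaker inhibitor), where it gives < 1 nM; this is a limit of the assay and not a number, (the limit of < 1 nM in this assay, at which 1 of the 3 values shown sits). Compound 3 `COc1cccc(CN(C)C(=O)c2c[nH]c3cc(-c4cn[nH]c4)ccc23)c1` gives 2 nM in this assay, and compound 2 `COc1cccc(CNC(=O)c2[nH]c3nc(-c4cn[nH]c4)ccc3c2CN2CCN(C)CC2)c1` gives 8 nM. Compound 4 `COc1cccc(CNC(=O)c2cn(-c3ccccc3)c3cc(-c4cn[nH]c4)ccc23)c1` differs from compound 1 by phenyl in place of hydrogen on an aromatic nitrogen. For the measured compounds named here, no measured pair changes this aromatic nitrogen; the only measured step, an at least 2.0-fold higher number from compound 1 to compound 3 (0.30 log units; that floor lies within the scatter), touches the amide nitrogen instead and shows that a substituent there costs little. Compound 4 is therefore expected to stay close to compound 1, with at most a modest loss, and the step of an at least 5.0-fold higher number from compound 1 to compound 4 (0.69 log units; beyond the scatter) is an estimate. For compound 4 the estimate in this assay is 5 nM, within a range from 1 nM to 30 nM.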

Compound 4, half-maximal inhibitory concentration: 5 nM
Beside the measured number, compound 4's estimate shows no gap at the digits printed; the range from low to high includes it.
By their numbers in this assay, from the lowest: compound 3; then compounds 4 and 2 (each within the scatter of the next). At a limit, below all of these: compound 1.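

Phenyl in place of hydrogen on the aromatic nitrogen gives an at least 5.0-fold higher number from compound 1 to compound 4 (0.69 log units; beyond the scatter), the first measured change at this position. Compound 4 still gives 5 nM in this assay, so this nitrogen can carry a phenyl ring and the compound remains an inhibitor at this level. The full size of the step cannot be read, as only its floor is known: the limit of < 1 nM in this assay, at which 1 of the 4 values shown sits.

The compounds shown leave open how a methyl, a benzyl or a chain ending in an amine on this nitrogen would compare with phenyl.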